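Ethoxycarbonyl to carboxy, starting from compound 3

The source may report more compounds than this note shows. Statements on the series, on what has been measured and on what is new or still open speak of the compounds shown alone.

Measured in a physicochemical assay for solubility, read by HPLC, in phosphate buffer, measured as kinetic solubility, at pH 7.4; a lower number here means a less soluble compound, a higher number a more soluble compound:
compound 1 `CCOC(=O)c1cc(-c2ccc(Cl)cc2)n(-c2ccc(S(N)(=O)=O)cc2)c1C`: 4200 nM
compound 2 `CCOC(=O)c1cc(-c2ccc(OC)cc2)n(-c2ccc(S(N)(=O)=O)cc2)c1C`: 16100 nM
compound 3 `CCOC(=O)c1cc(-c2ccc(C)cc2)n(-c2ccc(S(N)(=O)=O)cc2)c1C`: 1300 nM

Compound 3 has the lowest number of the three, as shown by a 3.2-fold lower number from compound 1 to compound 3 (0.51 log units; beyond the scatter) and a 12-fold lower number from compound 2 to compound 3 (1.09 log units; beyond the scatter). Compound 4 `Cc1ccc(-c2cc(C(=O)O)c(C)n2-c2ccc(S(N)(=O)=O)cc2)cc1` is not yet measured. It differs from compound 3 by hydrogen in place of ethyl on an oxygen next to a carbonyl group, which is hydrogen in place of ethyl on an oxygen next to a carbonyl group, or ethoxycarbonyl to carboxy.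

Among the compounds with values here, no measured step covers this change. All three exchange a group on an aromatic carbon, and the third, a 3.8-fold higher number from compound 1 to compound 2 (0.58 log units; beyond the scatter), is modest. These steps bear on the new one only as a gauge of how far this assay can move in this series on a single change, and the largest gauge is a 12-fold lower number from compound 2 to compound 3 (1.09 log units; beyond the scatter). A large upward move is expected, estimated as a 38-fold higher number from compound 3 to compound 4 (1.59 log units; beyond the scatter). Within the data shown here, with no direct precedent, the range is kept wide. For compound 4 the estimate is 50000 nM, with an expected range of 8000 nM to 250000 nM.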

Compound 4, solubility: 10000 nM
For compound 4 the middle estimate is 5.0-fold (0.70 log units) above the measured one; the range from low to high includes it.
By their numbers in this assay, from the lowest: compound 3; then compound 1; then compounds 4 and 2 (each within the scatter of the next).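

In this assay, within the data shown here, hydrogen in place of ethyl on an oxygen next to a carbonyl group gives a 7.7-fold higher number from compound 3 to compound 4 (0.89 log units; beyond the scatter) in this series, so this site can also move the read-out beyond the scatter, whereas the earlier steps covered only exchanges on an aromatic carbon. The size of this step is of the same order as the largest exchange on an aromatic carbon, a 12-fold lower number from compound 2 to compound 3 (1.09 log units; beyond the scatter) in the same assay. No supporting measurement bears on why the number moves at this site.

On these data alone, the change from ethoxycarbonyl to carboxy is read only with methyl on the aromatic carbon, and whether it gives a similar step with chloro or methoxy there remains open. Also open, as far as these compounds go, is how a primary amide, or a longer chain on the same oxygen, would read at this position.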